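The compounds below may be only part of what the source reports. "The series", "measured", "known", "first", "only" and "open" are said of these compounds alone.

Working notes on the series, read in a functional assay on PC-3 cells (Homo sapiens) for cytotoxicity, read by MTT assay; a higher number here means a weaker inhibitor, a lower number a stronger inhibitor. Compound 1 `COc1ccc2cc([C@H](C)c3nnc(SCc4ccc(C)cc4)n3-c3ccc(F)cc3)ccc2c1` gives 229000 nM. Compound 2 `COc1ccc2cc([C@H](C)c3nnc(SCc4ccc(F)cc4)n3-c3ccc(F)cc3)ccc2c1` has no exact number in this series. Compound 2 is reported only as a limit, <= 400000 nM. On these data alone, its standing against compound 1 therefore stays open.

Compound 3 `COc1cccc(CSc2nnc([C@@H](C)c3ccc4cc(OC)ccc4c3)n2-c2ccc(F)cc2)c1` differs from compound 2 in one place: 3-methoxyphenyl in place of 4-fluorophenyl on a saturated chain carbon bound to a sulfur. Cut one bond further out, the same difference reads 4-fluorobenzyl to 3-methoxybenzyl. Among the measured compounds shown here, the only measured step, a step that the limit leaves unreadable from compound 1 to compound 2, is fluoro in place of methyl on an aromatic carbon. It changes a different group and gives no size to carry over. For the measured compounds named here, no measured step covers the exchange made here, so no direction can be drawn from the data. Going by the values given here, the one exact number remains compound 1 at 229000 nM, and the expectation for the new compound stays in that region. The expected change, a step that the limit leaves unreadable from compound 2 to compound 3, is no larger than the usual scatter, and it is only a rough estimate since its starting point is a limit. Compound 3 is expected at 250000 nM, with an estimated range from 80000 nM to 600000 nM.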

Compound 3, half-maximal inhibitory concentration: 211000 nM
Compound 3: the middle estimate sits 1.2-fold (0.07 log units) above what was measured, and the stated range covers the measured number.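

In this assay, among the compounds shown here, the one step at this position with a readable size is a 1.1-fold lower number from compound 1 to compound 3 (0.04 log units; within the scatter), where 4-methylphenyl gives way to 3-methoxyphenyl. For the compounds shown here, this exchange of a group at the 4 position for a larger group at the 3 position therefore leaves the number unmoved beyond the scatter, which the earlier compounds could not show, and neither compound gives an order for the two groups. The steps that involve compound 2 cannot be read, because compound 2 is known only as a limit: the limit of <= 400000 nM in this assay, at which 1 of the 3 values shown sits.

On these data alone, how an amine or a carboxylic acid on this benzyl ring, or a longer chain in place of the benzyl link to the sulfur, would read remains open. The compounds shown all keep the shared core and vary only this one position, so whether any change moves the number beyond the scatter also stays open.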